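Methylcarbamoyl to Ethylcarbamoyl: Expected Clearance of Compound 4

The compounds below may be only part of what the source reports. "The series", "measured", "known", "first", "only" and "open" are said of these compounds alone.

In an ADME assay on microsomes from liver (Rattus norvegicus) for pharmacokinetics, using NADPH, with a stated time of 30 min, tested at 1 uM (on this read-out lower numbers stand for slow clearance and higher numbers for fast clearance), compound 2 `CNC(=O)c1c(-c2ccccc2)c([C@H](C)Nc2ncnc(N)c2C#N)nc2ccc(F)cc12` gives 15 mL.min-1.g-1 and stands level, within the scatter, with compound 1 `C[C@H](Nc1ncnc(N)c1C#N)c1nc2ccc(F)cc2c(-c2ccccn2)c1-c1ccccn1` at 16 mL.min-1.g-1 in this set. Compound 3 `C[C@H](Nc1ncnc(N)c1C#N)c1nc2ccc(F)cc2c(C(=O)N(C)C)c1-c1ccccc1` gives 426 mL.min-1.g-1 and lies far from both. Compound 4 `CCNC(=O)c1c(-c2ccccc2)c([C@H](C)Nc2ncnc(N)c2C#N)nc2ccc(F)cc12` has not yet been measured. Its difference from compound 2 is methyl in place of hydrogen on a saturated chain carbon bound to an amide-type nitrogen and it turns methylcarbamoyl into ethylcarbamoyl. Within the data shown here, one measured step bears on this change, a 28-fold higher number from compound 2 to compound 3 (1.45 log units; beyond the scatter) with methyl in place of hydrogen on an amide-type nitrogen. That step is large and beyond the scatter, but its methyl enters on the nitrogen itself and not on a saturated chain carbon, so it serves only as a loose guide to direction. An upward move of modest size is expected, estimated as a 2.0-fold higher number from compound 2 to compound 4 (0.30 log units; within the scatter) and well short of that large step. Compound 4 is therefore expected at 30 mL.min-1.g-1 (estimated range 12 mL.min-1.g-1 to 90 mL.min-1.g-1) in this assay once it is tested.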

Compound 4, intrinsic clearance in microsomes: < 14 mL.min-1.g-1
Compound 4 was reported as a limit; the forecaster's own chance of this, stated with the estimate: 2%; middle value at least 2.1-fold (0.33 log units) away from the limit.
By their numbers in this assay, from the lowest: compounds 2 and 1 (each within the scatter of the next); then compound 3. At a limit, below all of these: compound 4.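

In this assay, compound 4 is reported as a limit, < 14 mL.min-1.g-1. The step, an at least 1.0-fold lower number from compound 2 to compound 4 (0.02 log units; that floor lies within the scatter), shows that methyl in place of hydrogen on a saturated chain carbon bound to an amide-type nitrogen does not bring the large rise seen when the methyl enters on the amide-type nitrogen itself. The comparison with the dimethylamino amide reads an at least 30-fold lower number from compound 3 to compound 4 (1.48 log units; beyond the scatter), so ethylamino and dimethylamino on the carbonyl carbon stand far apart in this assay, and the high number in this set stays with compound 3.

Going by these compounds, the true number for compound 4 remains open: the limit of < 14 mL.min-1.g-1 in this assay, at which 1 of the 4 values shown sits. Also open, on these data alone, is whether a longer chain such as propyl, or a chain ending in a hydroxyl group, would keep the number this low on the same amide.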